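Shortening the Chain on the Ester Oxygen

The compounds below may be only part of what the source reports. "The series", "measured", "known", "first", "only" and "open" are said of these compounds alone.

Compound 2 `Cc1c(C(=O)OC(C)(C)C)c[nH]c1C(=O)OCC1CC1` gives the lowest of the two numbers recorded so far in an assay on CHO cells for inhibition of metabotropic glutamate receptor 1 (Rattus norvegicus) (on this read-out higher numbers stand for weaker inhibition and lower numbers for stronger inhibition), at 48 nM. Its nearest neighbour, compound 1 `Cc1c(C(=O)OC(C)(C)C)c[nH]c1C(=O)OC(C)(C)C`, gives 100 nM. Compound 3 `CCOC(=O)c1[nH]cc(C(=O)OC(C)(C)C)c1C` has not yet been measured; it differs from compound 2 by methyl in place of cyclopropyl on a saturated chain carbon bound to an oxygen next to a carbonyl group. Going by the values given here, one measured step bears on this change, as it also altered the group on the oxygen next to a carbonyl group: a 2.1-fold lower number from compound 1 to compound 2 (0.32 log units; beyond the scatter). That step, however, exchanged two groups of different shape, and it gives no direct guide to trimming the chain that now sits there. The step of a 1.5-fold higher number from compound 2 to compound 3 (0.16 log units; within the scatter) is therefore expected to be small, and may well fall within the scatter. For compound 3 the estimate in this assay is 70 nM, with a range from 30 nM to 170 nM.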

Compound 3, half-maximal inhibitory concentration: 340 nM
Compound 3: middle estimate off by 4.9-fold (0.69 log units), on the low side; measured number outside the range, above it.
By their numbers in this assay, from the lowest: compound 2; then compound 1; then compound 3.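

In this assay, methyl in place of cyclopropyl on a saturated chain carbon bound to an oxygen next to a carbonyl group gives a 7.1-fold higher number from compound 2 to compound 3 (0.85 log units; beyond the scatter) and shows that this position responds clearly to the chain it carries. Ethyl in place of tert-butyl on the same oxygen gives a 3.4-fold higher number from compound 1 to compound 3 (0.53 log units; beyond the scatter) and places ethyl last of the three groups compared here, so the lowest number belongs to cyclopropylmethyl and the highest to ethyl. No measurement at hand explains why these groups differ.

The compounds shown leave open whether a propyl chain, a longer chain or a cyclobutyl ring on this oxygen would give numbers closer to those of cyclopropylmethyl. They also leave open how an amide in place of this ester, or any group other than the tert-butyl ester kept throughout on the shared core, would read.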